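This account rests on a few compounds, and the source may have more. Where it says the series, first, only, none or still open, it means among the compounds named here.

In a physicochemical assay for lipophilicity (a higher number here means a more lipophilic compound, a lower number a more polar compound), compound 1 `NC(=O)c1ccc[n+](CC[C@H](NC(=O)[C@@H]2CCC(=O)N2)C(=O)N2CCC[C@H]2C(N)=O)c1` gives -2.18 and compound 2 `CC(C)(C)OC(=O)N1C(=O)CCC1C(=O)NC(C[n+]1cccc(C(N)=O)c1)C(=O)N1CCCC1C(N)=O` gives -2.49 as the lower of the two numbers, a gap beyond the usual scatter. Compound 3 `CC(C)(C)OC(=O)N1C(=O)CCC1C(=O)NC(CN1C=CCC(C(N)=O)=C1)C(=O)N1CCCC1C(N)=O` differs from compound 2 by one change, a group of 9 heavy atoms (6 carbon, 2 nitrogen, 1 oxygen; one six-membered non-aromatic ring with 1 hetero atom) in place of a group of 9 heavy atoms (6 carbon, 2 nitrogen, 1 oxygen; one six-membered aromatic ring with 1 hetero atom), on a saturated chain carbon, two bonds along the chain from an amide-type nitrogen and a carbonyl carbon on a saturated chain carbon, two bonds along the chain from an amide-type nitrogen and a carbonyl carbon. The group that leaves has net charge +1 and the group that enters has no net charge. Going by the values given here, no measured pair shows this kind of change, so a large rise in this assay remains an expectation. The estimated step is a number 2.69 log units higher from compound 2 to compound 3 (beyond the scatter) upward. Compound 3 is expected at 0.2 within an estimated range from -0.9 to 1.3 in this measurement.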

Compound 3, partition coefficient: -3.1
Estimate against measurement, compound 3: 3.30 log units above; measured number outside the range, below it.
By their numbers in this assay, from the lowest: compound 3; then compound 2; then compound 1.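

In this assay, the exchange on a saturated chain carbon gives the first step read at this position: a number 0.61 log units lower from compound 2 to compound 3 (beyond the scatter). The entering six-membered non-aromatic ring has no net charge where the leaving aromatic ring has net charge +1, so at this position losing that charge goes with a lower number, not a higher one. Nothing measured here explains that direction. The compounds shown leave open whether the same exchange gives a step of this direction with a carboxylic acid in place of the ring's carboxamide, or with a longer chain at this position.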